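Chain extension and a propanoyl amide at melatonin receptor type 1C

This account rests on a few compounds, and the source may have more. Where it says the series, first, only, none or still open, it means among the compounds named here.

Measured compounds:
- compound 1, `COc1ccc(F)c(CNC(C)=O)c1`, 100%
- compound 2, `CCC(=O)NCc1cc(OC)ccc1F`, 69%
- compound 3, `COc1ccc(F)c(CCCNC(C)=O)c1`, 100%

The three compounds were measured in an assay on isolated protein for agonist activity at melatonin receptor type 1C (Xenopus laevis), read by spectrophotometry; on this read-out higher numbers stand for larger maximal responses and lower numbers for smaller maximal responses. Compound 1 gives 100%, compound 2 gives 69% and compound 3 gives 100%. Compound 1 and compound 3 stand level at the digits printed, and together they hold the highest numbers of the three; the difference between their two cores is not broken down here.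

Compound 1 and compound 2 differ in one place, (methyl in place of hydrogen on a saturated chain carbon bound to a carbonyl carbon). That change brought a number 31 percentage points lower from compound 1 to compound 2 (beyond the scatter), a step beyond the scatter of this assay.

Compound 4, `CCC(=O)NCCCc1cc(OC)ccc1F`, has not yet been measured. It stands to compound 3 as compound 2 stands to compound 1: the difference is methyl in place of hydrogen on a saturated chain carbon bound to a carbonyl carbon, the same change at the same place. Among the compounds shown this change occurs twice in all, and only the first instance has a measured outcome.

If compound 4 follows the one measured precedent, the step from compound 3 is expected to be about as large as the one seen before, so that compound 4 is estimated at a number 30 percentage points lower from compound 3 to compound 4 (beyond the scatter). This expectation rests on compound 3 at 100% and on the earlier step of a number 31 percentage points lower from compound 1 to compound 2 (beyond the scatter). With one precedent only, the range is kept wide: compound 4 is expected to reach 70%, estimated between 50% and 95%.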

Compound 4, largest response reached (reported as efficacy), in percent of the reference or control that the assay uses: 100%
Estimate against measurement, compound 4: 30 percentage points below; measured number above the stated range.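

In this assay, exchanging acetyl for propanoyl on the core of compound 3 brought no change at the digits printed from compound 3 to compound 4 (within the scatter). Set beside the earlier instance, the same change did not give the same result on the two cores, and the gap between the two outcomes is larger than chance scatter would explain: the same change on two cores in this assay, a number 31 percentage points lower (beyond the scatter) from compound 1 to compound 2 and no change at the digits printed (within the scatter) from compound 3 to compound 4, 31 percentage points apart, beyond the scatter of two such steps This shows that, in these two pairs, the outcome of the change depends on the core that carries it, so the result on one core could not be transferred to the other; it does not show which feature of the cores is responsible, how general the difference is, or how the compounds compare in any measure other than largest response reached.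

With only two pairs, the compounds shown leave open whether the outcome on the core of compound 1 or the one on the core of compound 3 is the more usual in this series. They also leave open how a butanoyl group would behave on either core, and whether the propanoyl amide would keep its response on a core with a longer chain.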